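Chain extension toward compound 4 in the cell assay

This account rests on a few compounds, and the source may have more. Where it says the series, first, only, none or still open, it means among the compounds named here.

Three compounds share a core and differ only in the length of the chain that ends in the isothiocyanate. In a functional assay on NCI-H1299 cells (Homo sapiens) for inhibition, read by CCK-8 assay, with a stated time of 72 h, tested at 1 uM (on this read-out lower numbers stand for a weaker effect and higher numbers for a stronger effect at the one concentration tested), compound 1 `CN(C)C(=O)c1cc2cnc(Nc3ccc(C(=O)NCCCN=C=S)cc3)nc2n1C1CCCC1` gives 65.1%. Compound 2 `CN(C)C(=O)c1cc2cnc(Nc3ccc(C(=O)NCCCCCN=C=S)cc3)nc2n1C1CCCC1` gives 50.3% in this assay, and compound 3 `CN(C)C(=O)c1cc2cnc(Nc3ccc(C(=O)NCCCCCCN=C=S)cc3)nc2n1C1CCCC1` gives 49.4%. Compound 3 stands lowest of the three, within the scatter of compound 2 and beyond it only against compound 1. Compound 4 `CN(C)C(=O)c1cc2cnc(Nc3ccc(C(=O)NCCCCCCCN=C=S)cc3)nc2n1C1CCCC1` carries the change (a group of 4 heavy atoms (2 carbon, 1 nitrogen, 1 sulfur; no ring) in place of a group of 3 heavy atoms (1 carbon, 1 nitrogen, 1 sulfur; no ring), on a saturated chain carbon, six bonds along the chain from an amide-type nitrogen). Two lengthenings, a number 14.8 percentage points lower from compound 1 to compound 2 (beyond the scatter) and a number 15.7 percentage points lower from compound 1 to compound 3 (beyond the scatter), lowered the read-out, whereas the further one, a number 0.9 percentage points lower from compound 2 to compound 3 (within the scatter), did not. The next extension is therefore expected to give no step beyond the scatter, a number 2.4 percentage points lower from compound 3 to compound 4 (within the scatter). Compound 4 is estimated at 47%, between 35% and 58%.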

Compound 4, a percentage reported as inhibition, at one concentration (the size of the read-out at that concentration, not a potency): 75.7%
For compound 4 the middle estimate is 28.7 percentage points below the measured one; the whole stated range lies below it.
By their numbers in this assay, from the lowest: compounds 3 and 2 (each within the scatter of the next); then compound 1; then compound 4.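

In this assay the longest chain shown reverses the earlier fall, with a number 26.3 percentage points higher from compound 3 to compound 4 (beyond the scatter) and a number 25.4 percentage points higher from compound 2 to compound 4 (beyond the scatter), so the read-out at this position does not move in one direction with chain length. The longest chain also passes the shortest, with a number 10.6 percentage points higher from compound 1 to compound 4 (beyond the scatter), which makes compound 2 and compound 3 a dip in the series and not a floor. Nothing available here accounts for this turn. As far as these compounds go, whether a longer chain would hold the higher read-out remains open. So does whether an amine at the chain end, in place of the isothiocyanate, would retain it.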